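The source may report more compounds than this note shows. Statements on the series, on what has been measured and on what is new or still open speak of the compounds shown alone.

Compound 2 `COc1cc(Cl)cc(-c2nn(-c3cccc(NC(=O)Nc4ccc(Cl)c(Cl)c4)c3)cc2-c2ccncc2)c1` and compound 1 `COc1cc(Cl)cc(-c2nn(-c3cccc(NC(=O)Nc4cc(C(F)(F)F)cc(C(F)(F)F)c4)c3)cc2-c2ccncc2)c1` share the same core and differ only in the group on the amide-type nitrogen. In a functional assay on SK-MEL-28 cells (Homo sapiens) for inhibition, read by sulforhodamine B assay, with a stated time of 48 h, tested at 0.1 uM (a lower number here means a stronger effect, a higher number a weaker effect of the compound at the concentration tested), compound 1 gives 102% and compound 2 gives 103%; the two numbers lie within the scatter of each other, and neither shows an effect at this concentration. Compound 3 `COc1cc(Cl)cc(-c2nn(-c3cccc(NC(=O)Nc4cccc(C(F)(F)F)c4)c3)cc2-c2ccncc2)c1` is not yet measured. It differs from compound 2 by 3-(trifluoromethyl)phenyl in place of 3,4-dichlorophenyl on an amide-type nitrogen. Going by the values given here, no step of this kind has been measured, so no change beyond the scatter is expected in this assay, the expected step being a number 3 percentage points lower from compound 2 to compound 3 (within the scatter). Compound 3 is therefore estimated at 100%, within 88% to 110%.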

Compound 3, a percentage reported as activity, at one concentration (the size of the read-out at that concentration, not a potency): 100%
The estimate for compound 3 equals the measured number at the digits printed; measured number inside the range.
By their numbers in this assay, from the lowest: compounds 3, 1 and 2 (each within the scatter of the next).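

In this assay, 3-(trifluoromethyl)phenyl in place of 3,4-dichlorophenyl on an amide-type nitrogen gives a number 3 percentage points lower from compound 2 to compound 3 (within the scatter) and so leaves the read-out unchanged at this concentration. Hydrogen in place of trifluoromethyl on an aromatic carbon gives a number 2 percentage points lower from compound 1 to compound 3 (within the scatter) and so also shows no change, which means that this position has so far tolerated all three aryl groups without any effect appearing. No available evidence bears on this flat result. Going by these compounds, whether an amine or a carboxylic acid on the aromatic ring, or cyclohexyl in place of the aryl group, would produce an effect in this assay remains open.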